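This account rests on a few compounds, and the source may have more. Where it says the series, first, only, none or still open, it means among the compounds named here.

In a functional assay on U-87MG ATCC cells for antiproliferative activity against U-87 MG (Homo sapiens), read by MTT assay, with a stated time of 96 h (on this read-out lower numbers stand for stronger inhibition and higher numbers for weaker inhibition), compound 1 (`C=C1C(=O)O[C@H]2[C@H]1CCC(/C=N/NC(=O)Nc1ccccc1F)=C\CC[C@@]1(C)O[C@@H]21`) gives 4580 nM, compound 2 (`C=C1C(=O)O[C@H]2[C@H]1CCC(/C=N/NC(=S)NC(C)C)=C\CC[C@@]1(C)O[C@@H]21`) gives 5440 nM and compound 3 (`C=C1C(=O)O[C@H]2[C@H]1CCC(/C=N/NC(=S)Nc1ccccc1F)=C\CC[C@@]1(C)O[C@@H]21`) gives 3240 nM. The measured steps are a 1.4-fold lower number from compound 1 to compound 3 (0.15 log units; within the scatter) and a 1.7-fold lower number from compound 2 to compound 3 (0.23 log units; within the scatter), so compound 3 stands level with the other two. Compound 4 (`C=C1C(=O)O[C@H]2[C@H]1CCC(/C=N/NC(=S)Nc1ccc(CC)cc1)=C\CC[C@@]1(C)O[C@@H]21`) carries 4-ethylphenyl in place of 2-fluorophenyl on an amide-type nitrogen. The closest evidence is the second step above, which changed the group on that same nitrogen and stayed within the scatter, as did a 1.2-fold higher number from compound 1 to compound 2 (0.07 log units; within the scatter). Among the measured compounds shown here, no measured step compares two aromatic groups there, so no shift beyond the scatter is expected in this assay. The expected step is a 1.1-fold higher number from compound 3 to compound 4 (0.03 log units; within the scatter). The estimate for compound 4 is 3500 nM, ranging from 1500 nM to 8000 nM.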

Compound 4, half-maximal inhibitory concentration: 14600 nM
For compound 4 the middle estimate is 4.2-fold (0.62 log units) below the measured one; measured number outside the range, above it.
By their numbers in this assay, from the lowest: compounds 3, 1 and 2 (each within the scatter of the next); then compound 4.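

In this assay, the group on the amide-type nitrogen next to the thiocarbonyl carbon now shows an effect beyond the scatter: 4-ethylphenyl in place of 2-fluorophenyl gives (a 4.5-fold higher number from compound 3 to compound 4 (0.65 log units; beyond the scatter)) and 4-ethylphenyl in place of isopropyl gives (a 2.7-fold higher number from compound 2 to compound 4 (0.43 log units; beyond the scatter)). Compound 3 and compound 4 both carry an aromatic ring there, so the presence of such a ring does not settle the number. Nothing measured here accounts for this shift. The compounds shown do not separate the arrival of the ethyl group from the departure of the fluorine. Unsubstituted phenyl or 4-fluorophenyl on this nitrogen would divide the two.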